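Carboxy for vinyl on the imidazole side chain

The compounds below may be only part of what the source reports. "The series", "measured", "known", "first", "only" and "open" are said of these compounds alone.

Measured so far:
compound 1, `C=CCn1c(=O)c2[nH]cnc2n(CCC)c1=O`: 1700 nM
compound 2, `CCCn1c(=O)n(CC(C)=O)c(=O)c2[nH]cnc21`: 11400 nM
compound 3, `C=CCCn1cnc2c1c(=O)n(C)c(=O)n2CCC`: 6000 nM

These numbers come from an assay on Cerebral cortex for binding affinity to adenosine receptor A1 (Cavia porcellus), read by radioligand binding; a higher number here means a weaker inhibitor, a lower number a stronger inhibitor. Compound 3 gives a number that sits within the scatter of compound 2, so the two cannot be told apart, while compound 1 gives a number beyond the scatter below both, the strongest inhibition of the three.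

Compound 4, `CCCn1c(=O)n(C)c(=O)c2c1ncn2CCC(=O)O`, has not yet been measured. It differs from compound 3 by carboxy in place of vinyl on a saturated chain carbon, two bonds along the chain from an aromatic nitrogen; read on the whole chain, the but-3-en-1-yl group becomes 2-carboxyethyl. Within the data shown here, only one measured step bears on this: a 6.7-fold higher number from compound 1 to compound 2 (0.83 log units; beyond the scatter), where a polar acetyl replaced a vinyl on a chain at a different aromatic nitrogen of the shared core. That step weakened inhibition. The change in compound 4 is similar in kind, a polar group for a vinyl, though on the other chain, so a weaker inhibitor is expected, and the estimated step is a 3.3-fold higher number from compound 3 to compound 4 (0.52 log units; beyond the scatter). Compound 4 is therefore expected to give about 20000 nM, within a range from 6000 nM to 60000 nM.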

Compound 4, inhibition constant: > 200000 nM
Compound 4 was reported as a limit (the forecaster's own chance of this, stated with the estimate: 25%); middle value at least 10-fold (1.00 log units) away from the limit.
By their numbers in this assay, from the lowest: compound 1; then compounds 3 and 2 (each within the scatter of the next). At a limit, above all of these: compound 4.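

In this assay, carboxy in place of vinyl on a saturated chain carbon, two bonds along the chain from an aromatic nitrogen, gives a large step: an at least 33-fold higher number from compound 3 to compound 4 (1.52 log units; beyond the scatter). Among these compounds, the only earlier step, a 6.7-fold higher number from compound 1 to compound 2 (0.83 log units; beyond the scatter), was modest and lay on a chain at a different aromatic nitrogen, so it gave no sign that a change at this place could cost so much. The reading for compound 4 is a limit and not a number, so the step has a floor but no known size: the limit of > 200000 nM in this assay, at which 1 of the 4 values shown sits.

Going by these compounds, whether this loss belongs to the carboxylic acid itself or to any oxygen-bearing end on this chain remains open. A methyl ester, a primary amide or an alcohol at the same place could separate the two, and a carboxymethyl group on the other chain would show whether the place matters.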